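Three piperazine sulfonamides at the assay limit, and a fourth

This account rests on a few compounds, and the source may have more. Where it says the series, first, only, none or still open, it means among the compounds named here.

Compound 1 `CCCn1c(=O)[nH]c2nc(-c3ccc(S(=O)(=O)N4CCN(c5ccc(F)cc5)CC4)cc3)[nH]c2c1=O`: > 1000 nM
Compound 2 `CCCn1c(=O)[nH]c2nc(-c3ccc(S(=O)(=O)N4CCN(c5ccc(Br)cc5)CC4)cc3)[nH]c2c1=O`: > 1000 nM
Compound 3 `CCCn1c(=O)[nH]c2nc(-c3ccc(S(=O)(=O)N4CCN(c5cccc(Cl)c5)CC4)cc3)[nH]c2c1=O`: > 1000 nM

All three compounds share one core and differ only in the aryl group on the ring nitrogen of the piperazine. In an assay on CHO cells for displacement of a labelled ligand from adenosine receptor A1 (Homo sapiens), read by scintillation counting, with a stated time of 90 min, in the presence of a further agent that is not named here (a higher number here means a weaker inhibitor, a lower number a stronger inhibitor), compound 1 gives only a limit, > 1000 nM. Compound 2 likewise gives only a limit in this assay, > 1000 nM. Compound 3, the starting point here, also gives only a limit in this assay, > 1000 nM, so its true value is not known beyond that.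

The steps between the measured compounds are therefore unreadable: a step that the two limits leave unreadable from compound 1 to compound 2, a step that the two limits leave unreadable from compound 1 to compound 3 and a step that the two limits leave unreadable from compound 2 to compound 3. The one thing the data show is the limit of > 1000 nM in this assay, at which 3 of the 3 values shown sit.

Compound 4 `CCCn1c(=O)[nH]c2nc(-c3ccc(S(=O)(=O)N4CCN(c5ccc(C)cc5)CC4)cc3)[nH]c2c1=O` is not yet measured. It differs from compound 3 as follows: 4-methylphenyl in place of 3-chlorophenyl on an amine nitrogen in a ring. Among the compounds with values here, since every earlier change of the aryl group left the value at the limit, the expectation is that this change also leaves compound 4 at or near the limit, with no step readable beyond the scatter. The estimated step is a step that the limit leaves unreadable from compound 3 to compound 4. For compound 4 in this assay the estimate is 3000 nM, within 800 nM to 20000 nM.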

Compound 4, inhibition constant: > 1000 nM
Compound 4: only a limit was reported; the forecaster's own chance of this, stated with the estimate: 85%; the middle value does not contradict the limit.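

In this assay compound 4 gives > 1000 nM, which is a limit and not a number. The steps to compound 4 from compound 1, compound 2 and compound 3 therefore cannot be read, and the one readable feature stays the same: the limit of > 1000 nM in this assay, at which 4 of the 4 values shown sit.

The compounds shown leave open what the true values are, and whether these four aryl groups differ at all in this assay.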